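From pyridin-3-yl to 1,3-thiazol-5-yl on a carbonyl carbon

The source may report more compounds than this note shows. Statements on the series, on what has been measured and on what is new or still open speak of the compounds shown alone.

Compound 1 (`CC(C)(C)c1[nH]cnc1/C=c1\[nH]c(=O)/c(=C/c2cccc(C(=O)c3ccccc3)c2)[nH]c1=O`) carries phenyl on a carbonyl carbon. In a physicochemical assay for solubility, read by HPLC, with a stated time of 24 h (a higher number here means a more soluble compound, a lower number a less soluble compound), compound 1 gives < 0.1 ug/mL as a limit of the assay and not a number. In this assay compound 2 (`CC(C)(C)c1[nH]cnc1/C=c1\[nH]c(=O)/c(=C/c2cccc(C(=O)c3cccnc3)c2)[nH]c1=O`), with pyridin-3-yl at that place, likewise gives only a limit, < 0.1 ug/mL and no number. Where compound 2 stands is thus told only by the limit of < 0.1 ug/mL in this assay, at which 2 of the 2 values shown sit, and by no measured value.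

Compound 3 (`CC(C)(C)c1[nH]cnc1/C=c1\[nH]c(=O)/c(=C/c2cccc(C(=O)c3cncs3)c2)[nH]c1=O`) has 1,3-thiazol-5-yl in place of pyridin-3-yl on a carbonyl carbon. Among the compounds with values here, the one measured step that bears on this change is a step that the two limits leave unreadable from compound 1 to compound 2 and it is also a swap of one aromatic ring for another on a carbonyl carbon. That step offers no size to carry over, so no change beyond the scatter is expected, in either direction, and the estimated step is a number no lower from compound 2 to compound 3 (the limit leaves the size open) with a limit again the likeliest report. For compound 3 the estimate is 0.1 ug/mL with an expected range from 0.04 ug/mL to 0.4 ug/mL in this assay as the read-out.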

Compound 3, solubility: < 0.1 ug/mL
Compound 3 was reported as a limit; the forecaster's own chance of this, stated with the estimate: 70%; the middle value sits exactly at the limit.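

In this assay compound 3 gives < 0.1 ug/mL, a limit of the assay and not a number. No step among compound 1, compound 2 and compound 3 can be read, and the result stands only as this: the limit of < 0.1 ug/mL in this assay, at which 3 of the 3 values shown sit.

The compounds shown leave open how the three compare in this assay when the ring on the carbonyl carbon is exchanged.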